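Fluoro in place of hydrogen on compound 1

The compounds below may be only part of what the source reports. "The series", "measured", "known", "first", "only" and "open" are said of these compounds alone.

Measured so far in a functional assay on MCF7 cells (Homo sapiens) for inhibition, read by MTT assay, with a stated time of 48 h; on this read-out higher numbers stand for weaker inhibition and lower numbers for stronger inhibition
- compound 1 `O=C(CC(c1ccccc1)C(C(=O)Nc1ccccn1)C(=O)Nc1ccccn1)c1ccccc1` gives "not active" (no number reported)
- compound 2 `O=C(CC(c1ccc(Cl)cc1)C(C(=O)Nc1ccccn1)C(=O)Nc1ccccn1)c1ccccc1` gives 19100 nM

Compound 1 has no single number and stands only as "not active" (no number reported) in the record, so it offers no numeric anchor. For the measured compounds named here, the one number belongs to compound 2 at 19100 nM and no step between measured compounds can be computed. Compound 3 `O=C(CC(c1ccc(F)cc1)C(C(=O)Nc1ccccn1)C(=O)Nc1ccccn1)c1ccccc1` remains unmeasured. The structural change is fluoro in place of hydrogen on an aromatic carbon with fluoro in place of hydrogen on an aromatic carbon, para to a large group. A small step toward stronger inhibition is expected in this assay and would bring a weak value near that of compound 2 at 19100 nM while another report without a number remains possible. Compound 3 is estimated in this assay at 30000 nM with an expected range of 12000 nM to 90000 nM if a number is reported.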

Compound 3, half-maximal inhibitory concentration: 20900 nM
Estimate against measurement, compound 3: 1.4-fold (0.16 log units) above; low and high end bracket the measured number.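

In this assay compound 3 gives 20900 nM as its reading, and fluoro in place of chloro on the aromatic carbon gives a 1.1-fold higher number from compound 2 to compound 3 (0.04 log units; within the scatter), so the two groups cannot be told apart at this place. Compound 1, with hydrogen at this place, stands as "not active" (no number reported) in the record, whereas compound 2 and compound 3 both carry numbers, though the step from compound 1 to compound 3 cannot be read as a size. No measurement at hand accounts for this result.

Still open, going by these compounds, is whether a group of another kind at the same place, such as an amine or a methoxy group, would also give a number in this assay or would read like compound 1. Also open, on these data alone, is whether the reading follows from this place alone or from changes elsewhere on the core of compound 1.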